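The source may hold more compounds than are shown below. What is called first, only, known or untested is meant among the compounds shown, and "the series" means these compounds.

Series notes. The shared core carries an acid and, on a saturated chain carbon bound to an aromatic nitrogen, an alkyl group that is the point of variation. Compound 1 `CC(C)c1onc(-c2c(Cl)cccc2Cl)c1COc1ccc(-c2nc3ccc(C(=O)O)cc3n2CC2CCCCC2)c(F)c1` differs from the others at that carbon and at one further position; in an assay on isolated protein for agonist activity at Bile acid receptor (Homo sapiens), read by TR-FRET (on this read-out lower numbers stand for an effect already at smaller amounts and higher numbers for an effect only at larger amounts of compound), compound 1 gives "not determined" (no result reported). Compound 2 `CC(C)c1onc(-c2c(Cl)cccc2Cl)c1COc1ccc(-c2nc3ccc(C(=O)O)cc3n2CC(C)(C)C)cc1` carries tert-butyl on that chain carbon, and in this assay compound 2 gives 24.8 nM. Compound 3 `CCn1c(-c2ccc(OCc3c(-c4c(Cl)cccc4Cl)noc3C(C)C)cc2)nc2ccc(C(=O)O)cc21` carries methyl on that carbon, and in this assay compound 3 gives 19.3 nM. On the two numbers available, compound 3 and compound 2 cannot be separated: a 1.3-fold lower number from compound 2 to compound 3 (0.11 log units; within the scatter). Compound 4 `CC(C)Cn1c(-c2ccc(OCc3c(-c4c(Cl)cccc4Cl)noc3C(C)C)cc2)nc2ccc(C(=O)O)cc21` is the next member, and the change from compound 3 is isopropyl in place of methyl on a saturated chain carbon bound to an aromatic nitrogen. For the measured compounds named here, the one measured step that bears on it is the exchange at the same carbon, a 1.3-fold lower number from compound 2 to compound 3 (0.11 log units; within the scatter), which left the number where it was; isopropyl lies between methyl and tert-butyl, so no step beyond the scatter is expected in this assay, in either direction. The expected step for compound 4 is a 1.1-fold higher number from compound 3 to compound 4 (0.06 log units; within the scatter). Compound 4 is therefore estimated at 22 nM, within a range from 10 nM to 50 nM.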

Compound 4, half-maximal effective concentration: 24.7 nM
Beside the measured number, compound 4's estimate is 1.1-fold (0.05 log units) below it, within the range that was stated.
By their numbers in this assay, from the lowest: compounds 3, 4 and 2 (each within the scatter of the next).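

In this assay, isopropyl in place of methyl on a saturated chain carbon bound to an aromatic nitrogen gives a 1.3-fold higher number from compound 3 to compound 4 (0.11 log units; within the scatter), so a third alkyl group at this position cannot be separated from methyl. Hydrogen in place of methyl on a saturated chain carbon bound to three saturated chain carbons, the change that relates the tert-butyl and isopropyl groups, gives a 1.0-fold lower number from compound 2 to compound 4 (0.00 log units; within the scatter), which completes the comparison: compounds 2, 3 and 4 all lie within the scatter of one another, and the change in the size of the alkyl group between methyl and tert-butyl leaves no readable step in this series. Nothing available accounts for this flat result.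

From the compounds shown here alone, whether the position stays as flat with a group other than a plain alkyl chain, such as an amine, a hydroxyl group or a phenyl ring, remains open. In this assay, going by these compounds, compound 1 gives "not determined" (no result reported), so the effect of its cyclohexyl group and of its added fluorine also remains open.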